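Swapping a Formyl for a Methyl on a Dialdehyde Scaffold

The source may report more compounds than this note shows. Statements on the series, on what has been measured and on what is new or still open speak of the compounds shown alone.

Measured compounds and their readings:
compound 1 `Cc1c(C)c(O)c(C=O)c(C=O)c1O` gives 1%
compound 2 `O=Cc1c(C=O)c(O)c2ccccc2c1O` gives 17%
compound 3 `COc1c(C)c(C)c(OC)c(C=O)c1C=O` gives 15%

These three compounds were tested in a functional assay on the whole organism with Mus musculus as the target, at a dose of 10 mg/kg; a higher number here means a weaker effect of the compound at the dose given, a lower number a stronger effect. Among them compound 1 stands lowest, which here means the strongest effect at the dose given. Compound 3 comes nearest to it, though its number is higher by more than the usual scatter, and compound 2 lies furthest away, also beyond the scatter. So compound 1 is the most active of the three in this assay.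

Compound 4 `Cc1c(C)c(O)c(C=O)c(C)c1O` has not yet been measured. It differs from compound 1 in one place: methyl in place of formyl on an aromatic carbon. For the measured compounds named here, no pair of measured compounds differs in exactly this way, so the size of the step can only be guessed from the overall picture. Because compound 1 sits at 1%, the lowest of the three measured numbers, a change from it is more likely to raise the number than to lower it. The expectation is a modest loss of effect, a step of a number 14 percentage points higher from compound 1 to compound 4 (beyond the scatter) from compound 1 to compound 4, with the result possibly still inside the scatter. Compound 4 is therefore estimated at 15% in this assay, expected to fall between 2% and 45%.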

Compound 4, a percentage reported as activity, at one dose (the size of the read-out at that dose, not a potency): 25%
Compound 4: middle estimate off by 10 percentage points, on the low side, within the range that was stated.
By their numbers in this assay, from the lowest: compound 1; then compounds 3, 2 and 4 (each within the scatter of the next).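

In this assay, putting a methyl in place of the formyl on this aromatic carbon gives a number 24 percentage points higher from compound 1 to compound 4 (beyond the scatter), so the swap costs effect at the dose given. For the compounds shown here, this is the first reading of a single change at this position, ortho to a formyl group and ortho to a hydroxy group; compound 2 and compound 3 each differ from compound 1 in other ways and could not isolate it. Nothing available explains why the effect falls with this change.

Still open, on these data alone, is whether a carboxylic acid, an amine or a hydroxymethyl group at this position would keep the number close to that of compound 1. Also open, as far as these compounds go, is whether the same swap at the remaining formyl of compound 1 would produce a step of similar size.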